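Benzyl ring substituent swap in a nitrochalcone–triazole series

The source may hold more compounds than are shown below. What is called first, only, known or untested is meant among the compounds shown, and "the series" means these compounds.

Notes on a small set of chalcone ethers carrying a benzyl-substituted triazole. Compound 1 `O=C(/C=C/c1ccc(OCc2cn(Cc3ccccc3)nn2)cc1)c1ccc([N+](=O)[O-])cc1` has the plain benzyl group; in a functional assay on A549 cells (Homo sapiens) for inhibition, read by MTT assay, with a stated time of 48 h, tested at 10 uM (on this read-out higher numbers stand for more inhibition of growth at the one concentration tested and lower numbers for less inhibition of growth), compound 1 is reported as "not active" (no number reported). Compound 2 `O=C(/C=C/c1ccc(OCc2cn(Cc3cccc(Br)c3)nn2)cc1)c1ccc([N+](=O)[O-])cc1` carries a 3-bromobenzyl group in its place; in this assay compound 2 gives 28%. Within the data shown here, that is the only number in the set, so compound 2 stands alone on this read-out, with compound 1 beside it as an entry without a figure. Among the measured compounds shown here, no step between measured compounds is available.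

Compound 3 `O=C(/C=C/c1ccc(OCc2cn(Cc3cccc(F)c3)nn2)cc1)c1ccc([N+](=O)[O-])cc1` differs from compound 2 in one place: fluoro in place of bromo on an aromatic carbon. Nothing measured here tells how large a change this single exchange brings, and the comparison rests only on the two entries given. Given that compound 1 is reported as "not active" (no number reported), the expectation for compound 3 is a step downward from compound 2 of a number 13 percentage points lower from compound 2 to compound 3 (beyond the scatter), somewhat beyond the scatter. Compound 3 is therefore estimated at 15%, within a range of 0% to 35%, awaiting measurement.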

Compound 3, percent growth inhibition at one concentration: 33%
For compound 3 the middle estimate is 18 percentage points below the measured one; low and high end bracket the measured number.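

In this assay fluoro in place of bromo on an aromatic carbon brings a number 5 percentage points higher from compound 2 to compound 3 (within the scatter) and so leaves the two halogens at this place indistinguishable on this read-out. Growth inhibition in this small set is thus not tied to bromo: compound 3 gives 33% with fluoro in the same place, and compound 1, with the plain benzyl group, stands as "not active" (no number reported) with no figure beside it. The compounds at hand offer no evidence that would explain how either halogen differs from the plain benzyl group.

Going by these compounds, it remains open whether a group other than a halogen in this place, such as a methoxy group, an amine or a carboxylic acid, would give a figure beyond the scatter from those of compound 2 and compound 3. Also open, on these data alone, is how the series would read with the halogen moved to another carbon of the same ring, or with the nitro group of the shared core exchanged for a nitrile.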